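Methoxy to hydroxy on a shared urea-pyrazole core

The compounds below may be only part of what the source reports. "The series", "measured", "known", "first", "only" and "open" are said of these compounds alone.

Measured so far:
compound 1 `O=C(Nc1cccc(-n2cc(-c3ccncc3)c(-c3ccc(Cl)c(O)c3)n2)c1)Nc1cccc(C(F)(F)F)c1`: 1340 nM
compound 2 `COc1cc(-c2nn(-c3cccc(NC(=O)Nc4ccc(Cl)c(C(F)(F)F)c4)c3)cc2-c2ccncc2)ccc1Cl`: 919 nM

Both compounds were tested in a functional assay on MCF7 cells (Homo sapiens) for inhibition, read by sulforhodamine B assay, with a stated time of 48 h; on this read-out lower numbers stand for stronger inhibition of growth and higher numbers for weaker inhibition of growth. Compound 2 stands at the lower of the two numbers, but its gap to compound 1 lies within the scatter of such measurements. Compound 3 `O=C(Nc1cccc(-n2cc(-c3ccncc3)c(-c3ccc(Cl)c(O)c3)n2)c1)Nc1ccc(Cl)c(C(F)(F)F)c1` differs from compound 2 by hydrogen in place of methyl on an oxygen on an aromatic ring. Going by the values given here, no measured pair shows this change on its own, so its size is unknown; a step of no more than the scatter, in either direction, is expected. The expected step of a 1.1-fold higher number from compound 2 to compound 3 (0.04 log units; within the scatter) is therefore small. Compound 3 is estimated at 1000 nM, ranging from 400 nM to 2500 nM.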

Compound 3, concentration for 50% growth inhibition: 663 nM
Compound 3: middle estimate off by 1.5-fold (0.18 log units), on the high side; the range from low to high includes it.
By their numbers in this assay, from the lowest: compounds 3, 2 and 1 (each within the scatter of the next, the first and the last beyond it).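

In this assay, methoxy to hydroxy on the 4-chloro-3-methoxyphenyl group gives a 1.4-fold lower number from compound 2 to compound 3 (0.14 log units; within the scatter), so at this oxygen the change is not resolved from the scatter. Chloro in place of hydrogen on an aromatic carbon gives a 2.0-fold lower number from compound 1 to compound 3 (0.31 log units; beyond the scatter), a modest step and the only one here beyond the scatter. Nothing given here explains either step.

As far as these compounds go, whether an amine or an ethoxy group on the aromatic ring in place of the hydroxy would read differently remains open. So does the effect of fluoro or bromo in place of the new chloro.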